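The source may hold more compounds than are shown below. What is called first, only, known or untested is meant among the compounds shown, and "the series" means these compounds.

Compound 1 `Nc1scc(CN2CCN(c3ccc(F)cc3Cl)CC2)c1C(=O)c1ccc(Cl)cc1`: -70%
Compound 2 `Nc1scc(CN2CCN(C3CCCCCC3)CC2)c1C(=O)c1ccc(Cl)cc1`: -25%

For the measured compounds named here, of the two compounds measured in a functional assay on CHO cells with adenosine receptor A1 (Homo sapiens) as the target, read by cAMP accumulation and immunoassay, with a stated time of 6 min, tested at 10 uM (on this read-out higher numbers stand for a weaker effect at the one concentration tested and lower numbers for a stronger effect), compound 2 stands highest, and the single measured step that leads to it is a number 45 percentage points higher from compound 1 to compound 2 (beyond the scatter), a large shift beyond the scatter that came with cycloheptyl in place of 2-chloro-4-fluorophenyl on an amine nitrogen in a ring. Compound 3 `Nc1scc(CN2CCN(c3ccc(F)cc3F)CC2)c1C(=O)c1ccc(Cl)cc1` has not yet been measured. It differs from compound 2 in one place: 2,4-difluorophenyl in place of cycloheptyl on an amine nitrogen in a ring. Going by the values given here, this change returns a six-membered aromatic ring to the ring nitrogen that in compound 2 carries the seven-membered non-aromatic ring, so it largely reverses the only step seen so far, and a large fall in this assay is therefore expected, roughly as a number 35 percentage points lower from compound 2 to compound 3 (beyond the scatter). On that basis compound 3 is estimated at about -60%, with a range from -85% to -30%.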

Compound 3, a percentage reported as activity, at one concentration (the size of the read-out at that concentration, not a potency): -82%
Compound 3: middle estimate off by 22 percentage points, on the high side; measured number inside the range.
By their numbers in this assay, from the lowest: compound 3; then compound 1; then compound 2.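

In this assay, the cycloheptyl of compound 2 now stands against two different halogen-bearing phenyl groups on this amine nitrogen, and both give lower numbers: a number 57 percentage points lower from compound 2 to compound 3 (beyond the scatter), so the earlier gap does not rest on a single aryl group. The halogens on the phenyl ring also count, since fluoro in place of chloro on an aromatic carbon gives a number 12 percentage points lower from compound 1 to compound 3 (beyond the scatter), a modest step beside the large one from cycloheptyl. Nothing given here explains why these numbers move.

As far as these compounds go, whether a phenyl ring with no halogen, or one carrying a methoxy group, would keep these low numbers remains open. So does whether a smaller saturated ring such as cyclohexyl would behave like cycloheptyl on this nitrogen.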